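This account rests on a few compounds, and the source may have more. Where it says the series, first, only, none or still open, it means among the compounds named here.

Working notes on the series. Among the measured compounds shown here, in a physicochemical assay for solubility, read by HPLC, in phosphate buffer, measured as kinetic solubility, at pH 7.4 (on this read-out higher numbers stand for higher solubility and lower numbers for lower solubility), compound 3 `CC(=O)c1cc(-c2ccc(S(N)(=O)=O)cc2)n(-c2ccc(Cl)cc2)n1` gives 86800 nM and stands highest of the three numbers so far. Compound 1 `CCC(=O)c1cc(-c2ccc(Cl)cc2)n(C2CCN(S(N)(=O)=O)CC2)c1C` gives 27800 nM as the nearest number, lower than that of compound 3 and beyond the scatter. Compound 2 `CCC(=O)c1cc(-c2ccc(Cl)cc2)n(-c2ccc(S(C)(=O)=O)cc2)c1C` gives 4800 nM as the furthest number, also beyond the scatter. For the measured compounds named here, these three compounds differ in more than one place, so they supply no single-change step that could size the next one.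

Compound 4 `NS(=O)(=O)c1ccc(-c2cc(C(=O)CC3CCC3)nn2-c2ccc(Cl)cc2)cc1` is the next to be read. The change from compound 3 is cyclobutyl in place of hydrogen on a saturated chain carbon bound to a carbonyl carbon in which cyclobutyl takes the place of hydrogen on a saturated chain carbon bound to a carbonyl carbon, so that acetyl becomes (cyclobutylmethyl)carbonyl.

Going by the values given here, no measured example of this change exists, so the size of the step is a judgement and the range stays wide. The expected step of a 5.8-fold lower number from compound 3 to compound 4 (0.76 log units; beyond the scatter) runs toward a lower number in this assay and lies beyond the scatter. The estimate for compound 4 is 15000 nM (expected range 4000 nM to 50000 nM).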

Compound 4, solubility: 4300 nM
Beside the measured number, compound 4's estimate is 3.5-fold (0.54 log units) above it; the range from low to high includes it.
By their numbers in this assay, from the lowest: compounds 4 and 2 (each within the scatter of the next); then compound 1; then compound 3.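

In this assay the series now has its first single-change step: cyclobutyl in place of hydrogen on a saturated chain carbon bound to a carbonyl carbon gives a 20-fold lower number from compound 3 to compound 4 (1.31 log units; beyond the scatter), a large step. With the rest of compound 3 held in place, the change from acetyl to (cyclobutylmethyl)carbonyl, which adds 4 heavy atoms, all carbon, and 0 hydrogen-bond donors or acceptors, is enough by itself to move the read-out this far, so this position is not silent to this change. No measurement in hand accounts for the size of the step.

A single step cannot show whether the drop belongs to the cyclobutyl ring or would also follow from an open chain such as propyl at the same place, and it cannot show where an amine or a carboxylic acid on that chain carbon would fall. From the compounds shown here alone, whether the same change would move the number similarly on the cores of compound 1 and compound 2 also remains open.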